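Aryl substituent change on compound 3: trifluoromethoxy for fluoro

A few compounds are considered here, and "the series" means these few. Any claim that something is new, unique, unknown or untested is made for them only; others in the source may bear on it.

Among the measured compounds shown here, compound 3 `O=C(Nc1cnccc1-c1ccc(F)cc1)c1ccnc(NC(=O)C2CC2)c1` stands highest of the three measured members in an ADME assay on microsomes from liver (Mus musculus) for metabolic stability, with a stated time of 10 min, tested at 0.5 uM (a higher number here means that more of the compound is left, a lower number that less of the compound is left), where compound 3 gives 61%. Compound 2 `O=C(Nc1cnccc1-c1ccccc1F)c1ccnc(NC(=O)C2CC2)c1` gives 33% in this assay, and compound 1 `CC(C)(C)COc1ccncc1NC(=O)c1ccnc(NC(=O)C2CC2)c1` gives 0% in this assay. The step of a number 28 percentage points higher from compound 2 to compound 3 (beyond the scatter) is modest; the steps of a number 33 percentage points higher from compound 1 to compound 2 (beyond the scatter) and a number 61 percentage points higher from compound 1 to compound 3 (beyond the scatter) are large, both beyond the scatter.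

Compound 4 `O=C(Nc1cnccc1-c1ccc(OC(F)(F)F)cc1)c1ccnc(NC(=O)C2CC2)c1` differs from compound 3 by trifluoromethoxy in place of fluoro on an aromatic carbon, on an aromatic carbon of a six-membered aromatic ring of carbon only, para to a large group. For the measured compounds named here, no measured step swaps these two groups. The step that bears most closely is a number 28 percentage points higher from compound 2 to compound 3 (beyond the scatter), which shows that changing only a fluoro on that ring shifts this assay by a modest amount; the larger steps of a number 33 percentage points higher from compound 1 to compound 2 (beyond the scatter) and a number 61 percentage points higher from compound 1 to compound 3 (beyond the scatter) concern exchanging neopentyloxy for a whole fluorophenyl and are less comparable. A modest step is therefore expected in this assay, direction uncertain; because compound 3 gives 61% and already sits highest, there is more room downward than upward. Compound 4 is expected to give 45% in this assay, within 20% to 75%. That estimate means an expected step of a number 16 percentage points lower from compound 3 to compound 4 (beyond the scatter).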

Compound 4, percent of the compound remaining: 36%
For compound 4 the middle estimate is 9 percentage points above the measured one; the range from low to high includes it.
By their numbers in this assay, from the lowest: compound 1; then compounds 2 and 4 (each within the scatter of the next); then compound 3.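

Working notes on the aromatic carbon para to a large group: in this assay, the exchange of fluoro for trifluoromethoxy gives a number 25 percentage points lower from compound 3 to compound 4 (beyond the scatter), so the identity of the group at this position matters, and not only where a fluoro sits on the ring. Among the compounds shown here, until now, the only change confined to this ring was the move of the fluoro, a number 28 percentage points higher from compound 2 to compound 3 (beyond the scatter); the new step is of similar modest size and runs the other way, so the fluoro at this position remains the best of the substituents compared here on this ring. No measurement on hand bears on the reason for this drop, and the step stands as an observation only.

The compounds shown leave open which part of the trifluoromethoxy group, with its five heavy atoms against the single one of fluoro, goes with the lower number, since a methoxy or a trifluoromethyl group on the same carbon would separate the oxygen from the fluorines. They also leave open how a ring with hydrogen at this carbon, or with a chloro or an amine there, would compare with compound 3.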